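Ring size of the acyl group on a shared core

This account rests on a few compounds, and the source may have more. Where it says the series, first, only, none or still open, it means among the compounds named here.

Measured so far:
compound 1 `O=C(C1CCC1)N1CC2CC(C1)N2` — 99%
compound 2 `O=C(C1CCCC1)N1CC2CC(C1)N2` — 68%

Two compounds have been run in an assay on SH-EP1 cells for agonist activity at Neuronal acetylcholine receptor; alpha4/beta2 (Homo sapiens), read by FLIPR and calcium flux; on this read-out lower numbers stand for smaller maximal responses and higher numbers for larger maximal responses. Compound 1 gives 99% in this assay, and compound 2 gives 68% in this assay. Compound 1 thus stands highest of the two numbers; its nearest neighbour, compound 2, lies lower by a gap that is beyond the usual scatter. Going by the values given here, no step between these two compounds is counted here, so only their two values speak.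

Compound 3 `C[C@@H]1C[C@@H]1C(=O)N1CC2CC(C1)N2` is the next candidate. It differs from compound 1 by a group of 4 heavy atoms (4 carbon; one three-membered non-aromatic ring of carbon only) in place of a group of 4 heavy atoms (4 carbon; one four-membered non-aromatic ring of carbon only), on a carbonyl carbon. Among the compounds with values here, no measured step with such a change is at hand. Given that compound 1 reaches 99%, compound 3 is expected to stay near the upper end of what has been seen, with a step of a number 14 percentage points lower from compound 1 to compound 3 (beyond the scatter) of modest size, downward or none beyond the scatter. The expected value for compound 3 in this assay is 85%, within a range from 60% to 105%.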

Compound 3, largest response reached (Emax), in percent of the reference or control that the assay uses: 97%
Compound 3: middle estimate off by 12 percentage points, on the low side, and the stated range covers the measured number.
By their numbers in this assay, from the lowest: compound 2; then compounds 3 and 1 (each within the scatter of the next).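

In this assay, putting the group with a three-membered non-aromatic ring of carbon only in place of cyclobutyl, on the same carbonyl carbon, gives a number 2 percentage points lower from compound 1 to compound 3 (within the scatter), so at this position the two rings cannot be told apart on this read-out. The earlier pair showed only that the response can differ with the acyl group; now two ring groups of 4 heavy atoms stand together, while compound 2 at 68% remains apart from them. No measurement at hand accounts for this result.

The compounds shown leave open whether the 2 defined stereocentres of compound 3 bear on the response. They also leave open how the response would look with a group carrying no ring on the carbonyl carbon, such as a longer chain or an amine.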